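Morpholine amide nucleosides: a benzyl group in place of methyl

The compounds below may be only part of what the source reports. "The series", "measured", "known", "first", "only" and "open" are said of these compounds alone.

Measured so far:
compound 1, `CNC(=O)[C@H]1O[C@@H](n2cnc3c(NC)nc(Cl)nc32)[C@H](O)[C@@H]1O`, 0.282 nM
compound 2, `CNc1nc(Cl)nc2c1ncn2[C@@H]1O[C@H](C(=O)N2CCOCC2)[C@@H](O)[C@H]1O`, 3890 nM

In an assay on CHO cells for displacement of a labelled ligand from adenosine receptor A3 (Homo sapiens) (a lower number here means a stronger inhibitor, a higher number a weaker inhibitor), compound 2 gives the highest of the two numbers shown, with compound 1 as its only neighbour, separated by a 14000-fold higher number from compound 1 to compound 2 (4.14 log units; beyond the scatter). Compound 3, `O=C([C@H]1O[C@@H](n2cnc3c(NCc4cccc(I)c4)nc(Cl)nc32)[C@H](O)[C@@H]1O)N1CCOCC1`, has not yet been measured. It differs from compound 2 by 3-iodophenyl in place of hydrogen on a saturated chain carbon bound to a nitrogen on an aromatic ring. Within the data shown here, the only step measured so far concerns the group on the carbonyl carbon, not the group on the nitrogen on the aromatic ring, so no measured step bears directly on this change; the large size of that step shows only that this core can respond strongly to a single change. The entering group brings many more heavy atoms than the hydrogen it replaces, so a step beyond the scatter in either direction is plausible, and the estimate is correspondingly wide. Compound 3 is expected to give about 1000 nM in this assay, within 100 nM to 6000 nM, which would mean an estimated 3.9-fold lower number from compound 2 to compound 3 (0.59 log units; beyond the scatter).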

Compound 3, inhibition constant: 513 nM
Estimate against measurement, compound 3: 1.9-fold (0.29 log units) above, within the range that was stated.
By their numbers in this assay, from the lowest: compound 1; then compound 3; then compound 2.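

Among these compounds, with the morpholin-4-yl group on the carbonyl carbon held fixed, changing methylamino to (3-iodobenzyl)amino in this assay gives a 7.6-fold lower number from compound 2 to compound 3 (0.88 log units; beyond the scatter), the first reading at this position on the nitrogen on an aromatic ring. It shows that the position tolerates the 3-iodophenyl group on the saturated chain carbon and that this change moves the number toward a stronger inhibitor, a direction the earlier pair could not reveal. Set against a 14000-fold higher number from compound 1 to compound 2 (4.14 log units; beyond the scatter), this modest step is small, and no measurement here accounts for the effect of the 3-iodophenyl group.

The compounds shown leave open how much of the step belongs to the iodine and how much to the benzyl group itself, a question that a plain benzyl group or a 3-bromobenzyl group on the same nitrogen would address. They also leave open whether the 3-iodophenyl group gives a step of similar size and direction when the methylamino group remains on the carbonyl carbon, as it does in compound 1.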